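The compounds below may be only part of what the source reports. "The series", "measured", "known", "first", "only" and "open" are said of these compounds alone.

Working notes on the series. The shared core is a five-membered non-aromatic ring with one nitrogen and one oxygen joined at one shared atom to a saturated amine ring. Three compounds have numbers in an assay on cell membranes for displacement of a labelled ligand from Neuronal acetylcholine receptor; alpha4/beta2 (Rattus norvegicus); a lower number here means a stronger inhibitor, a higher number a weaker inhibitor. Compound 1 `BrC1=NOC2(CCCNC2)C1` carries a bromo on the carbon with a double bond to nitrogen and an unsubstituted ring amine; in this assay compound 1 gives 58000 nM. Compound 3 `c1ccc(C2=NOC3(CCCNC3)C2)cc1` carries a phenyl there instead; in this assay compound 3 returns only a limit, > 100000 nM. Within the data shown here, compound 2 `COC1=NOC2(CCCN(C)C2)C1` carries a methoxy on that carbon and a methyl on the ring amine; in this assay compound 2 likewise returns only a limit, > 100000 nM, so it stands at the limit of > 100000 nM in this assay, at which 2 of the 3 values shown sit, together with compound 3, with compound 1 the only member with a number.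

Compound 4 `CN1CCCC2(CC(Br)=NO2)C1` differs from compound 2 by bromo in place of methoxy on a carbon with a double bond to nitrogen, in words bromo in place of methoxy on a carbon with a double bond to nitrogen. Among the measured compounds shown here, no measured step covers this change. For the measured compounds named here, the one measured bromo compound, compound 1, gives a number in this assay, 58000 nM, so a move toward stronger binding is expected for compound 4, of a size an at least 1.2-fold lower number from compound 2 to compound 4 (0.09 log units; that floor lies within the scatter) that may or may not exceed the scatter. Compound 4 may still come back from this assay only as a limit. Compound 4 is estimated at 80000 nM in this assay, within 25000 nM to 300000 nM.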

Compound 4, inhibition constant: 44000 nM
Estimate against measurement, compound 4: 1.8-fold (0.26 log units) above; the measured number falls inside the stated range.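

Among these compounds, on the carbon with a double bond to nitrogen, bromo in place of methoxy gives the first step that can be read in this assay, with a methyl on the ring amine on both sides: an at least 2.2-fold lower number from compound 2 to compound 4 (0.35 log units; beyond the scatter). The true size of this step stays open because the value of compound 2 is only a limit, so the step printed is a floor: the limit of > 100000 nM in this assay, at which 2 of the 4 values shown sit.

Methyl in place of hydrogen on the ring amine, a change no earlier pair covered alone, gives a 1.3-fold lower number from compound 1 to compound 4 (0.12 log units; within the scatter), so with bromo on that carbon the two compounds stand within the scatter of each other.

Without a number for compound 2, the compounds shown cannot tell how far bromo and methoxy lie apart in this assay. They also leave open how chloro, a nitrile or an amine on the carbon with a double bond to nitrogen would read against bromo, and whether a longer chain on the ring amine would read as methyl does.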